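This account rests on a few compounds, and the source may have more. Where it says the series, first, only, none or still open, it means among the compounds named here.

Measured in a functional assay on SK-BR-3 cells (Homo sapiens) for inhibition, read by MTT assay; on this read-out lower numbers stand for stronger inhibition of growth and higher numbers for weaker inhibition of growth:
- compound 1 `CC1=C(/C=C/C(C)=C/C=C/C(C)=C\C(=O)Nc2ccccc2)C(C)(C)CCC1n1ccnc1`: 1730 nM
- compound 2 `CC1=C(/C=C/C(C)=C/C=C/C(C)=C\C(=O)Nc2cccc(F)c2)C(C)(C)CCC1n1ccnc1`: 17000 nM
- compound 3 `CC1=C(/C=C/C(C)=C/C=C/C(C)=C\C(=O)NCc2ccc(O)cc2)C(C)(C)CC=C1c1cncnc1`: 11500 nM

Compound 2 stands at the high-number end of this small set. Its value of 17000 nM lies within the usual scatter of compound 3 at 11500 nM, and well clear of compound 1 at 1730 nM.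

The step under discussion leads to compound 4 `CC1=C(/C=C/C(C)=C/C=C/C(C)=C\C(=O)Nc2ccccc2O)C(C)(C)CCC1n1ccnc1`, still unmeasured: 2-hydroxyphenyl in place of 3-fluorophenyl on an amide-type nitrogen. In words, 2-hydroxyphenyl replaces 3-fluorophenyl on an amide-type nitrogen.

Among the measured compounds shown here, only one measured step bears directly on this change: a 9.8-fold higher number from compound 1 to compound 2 (0.99 log units; beyond the scatter), beyond the scatter, with fluoro in place of hydrogen on an aromatic carbon. Compound 4 no longer carries that fluoro, so the closer reference is compound 1 at 1730 nM. For the measured compounds named here, no measured step shows what the entering hydroxyl does on this anilide, and compound 3 differs from the others in more than one place, so it cannot isolate that effect. A return of much, but not necessarily all, of the earlier loss therefore seems reasonable. The expected step is a 4.3-fold lower number from compound 2 to compound 4 (0.63 log units; beyond the scatter), towards a lower number, with considerable uncertainty. For compound 4 the estimated value is 4000 nM, with an expected range of 1200 nM to 14000 nM.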

Compound 4, concentration for 50% growth inhibition: 3890 nM
Compound 4: the middle estimate sits 1.0-fold (0.01 log units) above what was measured, and the stated range covers the measured number.
By their numbers in this assay, from the lowest: compound 1; then compound 4; then compounds 3 and 2 (each within the scatter of the next).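

In this assay, 2-hydroxyphenyl on the amide-type nitrogen gives a 4.4-fold lower number from compound 2 to compound 4 (0.64 log units; beyond the scatter) and so shows that a substituted phenyl at this place need not carry the full penalty seen with 3-fluorophenyl. Set against the unsubstituted phenyl, the hydroxy group still gives a 2.2-fold higher number from compound 1 to compound 4 (0.35 log units; beyond the scatter) and thus a second substituted ring with a number above that of compound 1, alongside a 9.8-fold higher number from compound 1 to compound 2 (0.99 log units; beyond the scatter) for the fluoro group; among these three compounds, neither substituted phenyl goes against that pattern. Nothing available here accounts for the size of either step.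

The compounds shown leave open how much of the change from 3-fluorophenyl to 2-hydroxyphenyl belongs to the exchange of fluoro for hydroxy and how much to the different place of the group on the phenyl ring, as the two names themselves show. They also leave open whether an amine or a carboxylic acid on this phenyl, or a longer chain between the amide-type nitrogen and the ring, would match or improve on compound 1 at 1730 nM.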